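The compounds below may be only part of what the source reports. "The series", "measured", "known", "first", "only" and "open" are said of these compounds alone.

Working notes on the urea series. In an assay on isolated protein for inhibition of ATP-dependent RNA helicase DDX3X (Homo sapiens), read by FRET, with stated times of 30 s and 40 min (on this read-out higher numbers stand for weaker inhibition and lower numbers for stronger inhibition), compound 1 `CCCCc1cn(-c2ccc(NC(=O)Nc3cc(CCC(C)=O)ccc3C)cc2)nn1` gives 2490 nM. Two further members have been measured in this assay: compound 2 `Cc1ccccc1NC(=O)Nc1ccc(-n2cc(CCO)nn2)cc1` gives 13000 nM, and compound 3 `CCOC(=O)CCc1cn(-c2ccc(NC(=O)Nc3ccccc3C(F)(F)F)cc2)nn1` gives 2020 nM. Among these three numbers compound 1 holds the second highest. The number of compound 3 lies within the scatter of that of compound 1, so the two cannot be ordered. The number of compound 2 lies beyond the scatter, on the higher side, meaning weaker inhibition than compound 1.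

The next compound, compound 4 `CCCCc1cn(-c2ccc(NC(=O)Nc3cc(OC4CCOC4)ccc3C)cc2)nn1`, departs from compound 1 in one place: (oxolan-3-yl)oxy in place of 2-acetylethyl on an aromatic carbon. Going by the values given here, no measured pair shares this kind of exchange, so no step size can be taken from the data to guide the expectation. The change keeps the shared core of compound 1 and the butyl triazole untouched and swaps only the substituent on the aromatic carbon that is meta to the large group and para to the methyl group.

Among the compounds with values here, with no comparable step recorded, the step from compound 1 to compound 4 in this assay is expected to be a 1.2-fold higher number from compound 1 to compound 4 (0.08 log units; within the scatter), that is, no change beyond the scatter. Compound 4 is accordingly estimated at 3000 nM, with a range from 1200 nM to 8000 nM.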

Compound 4, half-maximal inhibitory concentration: 100 nM
Compound 4: middle estimate off by 30-fold (1.48 log units), on the high side; measured number outside the range, below it.
By their numbers in this assay, from the lowest: compound 4; then compounds 3 and 1 (each within the scatter of the next); then compound 2.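

In this assay, the aromatic carbon that is meta to a large group and para to a methyl group proves highly sensitive to its substituent: with the rest of compound 1 unchanged, (oxolan-3-yl)oxy in place of 2-acetylethyl gives a 25-fold lower number from compound 1 to compound 4 (1.40 log units; beyond the scatter), a large step beyond the scatter. Going by these compounds alone, compounds 2 and 3 each differ from compound 1 in more than one place, so they could not assign any change in the number to this position alone; this pair does so, and it shows that a single exchange here can outweigh the spread among the earlier compounds. The exchange replaces an open chain carrying a carbonyl with an oxygen-linked five-membered non-aromatic ring, but no measurement in hand bears on why the number falls so far.

Still open, from the compounds shown here alone, is whether the step follows the ring itself or the oxygen linking it to the aromatic carbon, a question that a methoxy group, a 2-methoxyethoxy chain or a cyclopentyloxy group at this position would address. Also open, going by these compounds, is whether a ring amine such as pyrrolidin-3-yloxy would fit the same trend.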